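This account rests on a few compounds, and the source may have more. Where it says the series, first, only, none or still open, it means among the compounds named here.

Compound 1 `CCOC(=O)c1cn(Cc2c(F)cccc2F)c2nc(-c3ccc(NC(=O)NCc4cn(CCOCCOCCOCCN=[N+]=[N-])nn4)cc3)c(CN(C)Cc3ccccc3)n2c1=O` gives 3020 nM in a functional assay on CHO cells for antagonist activity at Gonadotropin-releasing hormone receptor (Homo sapiens), read by a luciferase reporter, with a stated time of 30 min; a lower number here means a stronger inhibitor, a higher number a weaker inhibitor. Compound 2 `CCOC(=O)c1cn(Cc2c(F)cccc2F)c2nc(-c3ccc(NC(=O)NCc4cn(CCN=[N+]=[N-])nn4)cc3)c(CN(C)Cc3ccccc3)n2c1=O` gives 2570 nM in this assay. Compound 3 `CCNC(=O)Nc1ccc(-c2nc3n(Cc4c(F)cccc4F)cc(C(=O)NCc4cn(CCOCCOCCOCCN=[N+]=[N-])nn4)c(=O)n3c2CN(C)Cc2ccccc2)cc1` gives < 10000 nM in this assay, and this is a limit of the assay rather than a number.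

Compound 1 and compound 2 differ in one place, (azido in place of 2-(2-(2-azidoethoxy)ethoxy)ethoxy on a saturated chain carbon, two bonds along the chain from an aromatic nitrogen), and this change made a 1.2-fold lower number from compound 1 to compound 2 (0.07 log units; within the scatter). The difference between the core of compound 1 and the core of compound 3 is not broken down here. Compound 4 `CCNC(=O)Nc1ccc(-c2nc3n(Cc4c(F)cccc4F)cc(C(=O)NCc4cn(CCN=[N+]=[N-])nn4)c(=O)n3c2CN(C)Cc2ccccc2)cc1` has not yet been measured; it carries the same change relative to compound 3, (azido in place of 2-(2-(2-azidoethoxy)ethoxy)ethoxy on a saturated chain carbon, two bonds along the chain from an aromatic nitrogen), at the same place. Since the step of a 1.2-fold lower number from compound 1 to compound 2 (0.07 log units; within the scatter) was small, the step from compound 3 to compound 4 is expected to be small too, about a step that the limit leaves unreadable from compound 3 to compound 4. For compound 4 the estimate in this assay is 4000 nM, between 1500 nM and 10000 nM.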

Compound 4, half-maximal inhibitory concentration: < 10000 nM
Compound 4 ended at the assay's limit (the forecaster's own chance of this, stated with the estimate: 40%); the middle value lies beyond the limit too.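

No step from compound 3 to compound 4 can be read, because each compound gives only a limit and not a number: the limit of < 10000 nM in this assay, at which 2 of the 4 values shown sit.

Still open, on these data alone, is how strong compound 3 and compound 4 really are, and whether the change between them matters as little as it did from compound 1 to compound 2.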